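The source may report more compounds than this note shows. Statements on the series, on what has been measured and on what is new or still open speak of the compounds shown alone.

Of the compounds shown here, three have so far been measured in an ADME assay on HEK-293T cells (Homo sapiens) for inhibition, read by luminescence, with a stated time of 72 h, tested at 5 uM; on this read-out higher numbers stand for more inhibition of growth at the one concentration tested and lower numbers for less inhibition of growth. Compound 1 `COc1cc(O)c(C(=O)OCC2CCCCC2)c(/C=C/CN2C(=O)C=CC2=O)c1` gives 6.9%. Compound 3 `COc1cc(O)c(C(=O)OCC(C)c2ccccc2)c(/C=C/CN2C(=O)C=CC2=O)c1` differs from compound 1 in one place; in this assay compound 3 gives 0%, and the step of a number 6.9 percentage points lower from compound 1 to compound 3 (within the scatter) stays within the scatter. Compound 2 `C=CS(=O)(=O)NC/C=C/c1cc(OC)cc(O)c1C(=O)OCc1ccc(Br)cc1` gives 0%, level with compound 3 at the digits shown and together with it the lowest of the three numbers, while compound 1 differs from it only within the scatter. In short, none of the three shows growth inhibition beyond the scatter at the one concentration tested.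

Compound 4 `C=CS(=O)(=O)NC/C=C/c1cc(OC)cc(O)c1C(=O)OCc1ccc(F)cc1` has not yet been measured. It differs from compound 2 by fluoro in place of bromo on an aromatic carbon. Among the compounds with values here, no measured step exchanges one halogen for another; the only measured step, from compound 1 to compound 3, alters a different part of the molecule and stays within the scatter. With all three measured numbers sitting close to zero, nothing in the data suggests compound 4 will move beyond the scatter, so the expected step of a number 2 percentage points higher from compound 2 to compound 4 (within the scatter) is essentially none. Compound 4 is therefore estimated at 2%, with a range from -8% to 12%.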

Compound 4, percent growth inhibition at one concentration: 0%
The estimate for compound 4 lay 2 percentage points above the measured number; measured number inside the range.
By their numbers in this assay, from the lowest: compounds 2, 3, 4 and 1 (each within the scatter of the next).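

In this assay, fluoro in place of bromo, on an aromatic carbon para to a large group, gives no change at the digits printed from compound 2 to compound 4 (within the scatter). Within the data shown here, this is the first measured step at this position: the earlier step from compound 1 to compound 3 changed a different part of the molecule, so it said nothing about the halogen on the 4-bromobenzyl group. It shows that, at the one concentration tested, exchanging these two halogens does not bring growth inhibition beyond the usual scatter, although with both compounds reading zero, the step cannot show whether the halogen matters in any other setting. Nothing measured here offers an explanation for this result.

The compounds shown leave open whether anything other than these two halogens on this aromatic carbon would give a different reading, for example an amine, a carboxylic acid, a nitrile or a longer chain such as propyl. They also leave open how a plain 4-unsubstituted benzyl group would read, and whether compound 2 and compound 4 would still read alike at another concentration.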